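Methoxy for fluoro on the fused ring system

The compounds below may be only part of what the source reports. "The series", "measured", "known", "first", "only" and "open" are said of these compounds alone.

The series is read in a functional assay on HeLa cells (Homo sapiens) for antiproliferative activity, read by MTT assay, with a stated time of 48 h; a lower number here means a stronger inhibitor, a higher number a weaker inhibitor. Going by the values given here, compound 1 `CS(=O)(=O)c1ccc(Nc2nccc(Nc3nc4ccc(F)cc4s3)n2)cc1` gives 560 nM in this assay and is the only member with a numerical value. Compound 2 `CS(=O)(=O)c1ccc(Nc2ncc(F)c(Nc3nc4ccc(F)cc4s3)n2)cc1` returns > 50000 nM, which is a limit of this assay rather than a number (the limit of > 50000 nM in this assay, at which 1 of the 2 values shown sits). Among the compounds with values here, the one measured step, an at least 89-fold higher number from compound 1 to compound 2 (1.95 log units; beyond the scatter), sits on the shared core and not on the fused system of two rings.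

Compound 3 `COc1ccc2nc(Nc3ccnc(Nc4ccc(S(C)(=O)=O)cc4)n3)sc2c1` differs from compound 1 by methoxy in place of fluoro on an aromatic carbon. Within the data shown here, no measured step touches the fused system of two rings, so the step from compound 1 to compound 2 gives no guide to the direction or size of this change, and no step beyond the scatter is assumed. Compound 3 is therefore expected to sit close to compound 1 in this assay. For compound 3 the expected step is a 1.1-fold higher number from compound 1 to compound 3 (0.03 log units; within the scatter). The estimate for compound 3 in this assay is 600 nM, with a range from 200 nM to 2500 nM.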

Compound 3, half-maximal inhibitory concentration: 4130 nM
For compound 3 the middle estimate is 6.9-fold (0.84 log units) below the measured one; the whole stated range lies below it.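

The fused system of two rings is not a silent part of the series: in this assay, methoxy in place of fluoro on its aromatic carbon gives a 7.4-fold higher number from compound 1 to compound 3 (0.87 log units; beyond the scatter), the first step read at this position. The change goes toward the weaker end of the assay, yet compound 3 still returns a numerical value, so this position carries methoxy with a loss that remains modest in size. Nothing shown explains why methoxy reads weaker than fluoro at this position.

On these data alone, with a single pair at this position, the data give no trend: how hydrogen, chloro, an amine or a longer chain such as ethoxy would read here remains open, as does whether any group at this place can improve on compound 1. Also open, as far as these compounds go, is whether the fluoro in place of hydrogen on the shared core would have the same consequence with methoxy on the fused system, since the two changes are seen only separately, each starting from compound 1.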